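Bromo substitution across two core variants, antiproliferative series

The source may report more compounds than this note shows. Statements on the series, on what has been measured and on what is new or still open speak of the compounds shown alone.

Measured so far:
compound 1 `NS(=O)(=O)c1ccc(C(=O)N/N=C(/CS(=O)(=O)c2ccccc2)c2ccccc2)cc1` 84800 nM
compound 2 `NS(=O)(=O)c1ccc(C(=O)N/N=C(/CS(=O)(=O)c2ccccc2)c2ccc(Br)cc2)cc1` 34100 nM
compound 3 `NS(=O)(=O)c1ccc(N/C=C(\C(=O)c2ccccc2)S(=O)(=O)c2ccccc2)cc1` 17900 nM

All three were tested in an ADME assay on MCF-10A cells (Homo sapiens) for antiproliferative activity, read by MTT assay; a lower number here means a stronger inhibitor, a higher number a weaker inhibitor. Compound 1 and compound 2 share one core; compound 3 is built on a second core, and the difference between the two cores is not broken down here.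

Within the first core, the step of a 2.5-fold lower number from compound 1 to compound 2 (0.40 log units; beyond the scatter) comes from the change (bromo in place of hydrogen on an aromatic carbon). Compound 3 gives the lowest number of the three, but against compound 2 this lies within the scatter, so no order between compound 3 and compound 2 can be claimed; against compound 1 the gap is beyond the scatter.

Compound 4 `NS(=O)(=O)c1ccc(N/C=C(\C(=O)c2ccc(Br)cc2)S(=O)(=O)c2ccccc2)cc1` is not yet measured. It differs from compound 3 by bromo in place of hydrogen on an aromatic carbon, the same change that turns compound 1 into compound 2. The place of the change reads identically for both pairs. For the measured compounds named here, the only guide to its effect is the single step seen on the first core; whether it carries over to the second core is untested, and the two cores are not directly comparable here.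

On that basis the step from compound 3 to compound 4 in this assay is expected to be about a 2.2-fold lower number from compound 3 to compound 4 (0.35 log units; beyond the scatter), resting on the step of a 2.5-fold lower number from compound 1 to compound 2 (0.40 log units; beyond the scatter). Compound 4 is therefore estimated at 8000 nM, expected to fall between 3500 nM and 20000 nM.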

Compound 4, half-maximal inhibitory concentration: 20400 nM
Compound 4: the middle estimate sits 2.6-fold (0.41 log units) below what was measured, and the stated range ends below it.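

In this assay, bromo in place of hydrogen on the core of compound 3 gives a 1.1-fold higher number from compound 3 to compound 4 (0.06 log units; within the scatter), so no shift from this change can be claimed on that core. Set beside the step on the core of compound 1, the same change does not carry over with the same size: the same change on two cores in this assay, a 2.5-fold lower number (0.40 log units; beyond the scatter) from compound 1 to compound 2 and a 1.1-fold higher number (0.06 log units; within the scatter) from compound 3 to compound 4, 2.8-fold (0.45 log units) apart, beyond the scatter of two such steps In this series, then, a step for this change read on one core is not a safe guide to the step on the other, even though the change reads identically in both pairs, from phenyl to 4-bromophenyl in one and from benzoyl to (4-bromophenyl)carbonyl in the other. This rests on a single pair for each core; it does not show what separates the two cores, nor does it set a rule for any other core or any other group.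

Going by these compounds, whether a chloro, a methoxy, an amine or a carboxylic acid at the same place would give steps that agree across the two cores remains open. Also open, on these data alone, is whether the gap between the steps belongs to bromo alone or would recur with every group placed there.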